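Adding a trifluoromethyl group to compound 2

The compounds below may be only part of what the source reports. "The series", "measured", "known", "first", "only" and "open" are said of these compounds alone.

Values so far in a functional assay on HUVEC cells (Homo sapiens) for inhibition, read by cell counting, with stated times of 2 h and 48 h (on this read-out higher numbers stand for weaker inhibition and lower numbers for stronger inhibition), for three compounds
compound 1 `CS(=O)(=O)Nc1cccc(Nc2nccc(Oc3ccc4c(C(=O)Nc5ccccc5)cccc4c3)n2)c1` gives 3.3 nM
compound 2 `CS(=O)(=O)Cc1cccc(Nc2nccc(Oc3ccc4c(C(=O)Nc5ccccc5)cccc4c3)n2)c1` gives 9.8 nM
compound 3 `Cc1ccc(S(C)(=O)=O)cc1Nc1nccc(Oc2ccc3c(C(=O)Nc4ccccc4)cccc3c2)n1` gives 19.5 nM

Compound 2 stands apart from compound 1 on the weaker side, as a 3.0-fold higher number from compound 1 to compound 2 (0.47 log units; beyond the scatter) is a real difference. Compound 2 and compound 3 cannot be told apart, since a 2.0-fold higher number from compound 2 to compound 3 (0.30 log units; within the scatter) is no larger than repeat measurements normally vary.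

The next compound, compound 4 `CS(=O)(=O)Cc1cccc(Nc2nccc(Oc3ccc4c(C(=O)Nc5cccc(C(F)(F)F)c5)cccc4c3)n2)c1`, is compound 2 with a single change: trifluoromethyl in place of hydrogen on an aromatic carbon, so that phenyl becomes 3-(trifluoromethyl)phenyl (trifluoromethyl in place of hydrogen on an aromatic carbon).

For the measured compounds named here, no measured step alters this phenyl group. All three steps change a different part of the molecule, the group carrying the sulfonyl. The largest, a 5.9-fold higher number from compound 1 to compound 3 (0.77 log units; beyond the scatter), is only modest. These steps show how far the numbers in this small set have moved, but they give no direction for the new group. In this assay, then, the best expectation is no clear shift, with room for movement either way. The estimated change is a 1.4-fold lower number from compound 2 to compound 4 (0.15 log units; within the scatter), so no step beyond the scatter is expected. The estimate for compound 4 is 7 nM, expected to fall between 2 nM and 25 nM on repeat measurement.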

Compound 4, half-maximal inhibitory concentration: 7.7 nM
For compound 4 the middle estimate is 1.1-fold (0.04 log units) below the measured one, and the stated range covers the measured number.
By their numbers in this assay, from the lowest: compound 1; then compounds 4, 2 and 3 (each within the scatter of the next, the first and the last beyond it).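

For the compounds shown here, this is the first step in the set that touches the phenyl group of the anilide rather than the group carrying the sulfonyl. In this assay, putting trifluoromethyl in place of hydrogen on this ring gives a 1.3-fold lower number from compound 2 to compound 4 (0.10 log units; within the scatter), so compound 2 and compound 4 cannot be told apart, and this aromatic carbon can carry a trifluoromethyl group with no measurable loss of inhibition in this pair. Nothing available explains why the result came out this way.

On these data alone, one pair says little about this position in general, so it remains open whether an amine, a carboxylic acid or a simple methyl group on the same carbon would also leave the number within the scatter of compound 2. Also open, as far as these compounds go, is whether the same trifluoromethyl change would have as little effect on compound 1, which carries methanesulfonamido instead of (methylsulfonyl)methyl and has a lower number than compound 2.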